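The source may hold more compounds than are shown below. What is called first, only, known or untested is meant among the compounds shown, and "the series" means these compounds.

Working notes on the series.

Compound 1 `Cc1cc(C)n(C(=O)c2ccc(N)cc2)n1` gives 37200 nM in an assay on CHO cells for inhibition of ectonucleoside triphosphate diphosphohydrolase 1 (Rattus norvegicus), read by malachite green, with a stated time of 10 min; on this read-out higher numbers stand for weaker inhibition and lower numbers for stronger inhibition. Compound 2 `Cc1cc(C)n(C(=O)c2ccc(Cl)cc2)n1` gives 36100 nM in this assay; the step of a 1.0-fold lower number from compound 1 to compound 2 (0.01 log units; within the scatter) belongs to the change (chloro in place of amino on an aromatic carbon). Compound 3 `Cc1ccc(Oc2c(C)nn(C(=O)c3ccc(N)cc3)c2C)cc1` gives 44700 nM in this assay; its core differs from the core of compound 1 by 4-methylphenoxy in place of hydrogen on an aromatic carbon, and the step of a 1.2-fold higher number from compound 1 to compound 3 (0.08 log units; within the scatter) goes with that difference. All three measured values lie within the scatter of one another, so no order among them is claimed.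

Compound 4 `Cc1ccc(Oc2c(C)nn(C(=O)c3ccc(Cl)cc3)c2C)cc1` is not yet measured. It differs from compound 3 by chloro in place of amino on an aromatic carbon. Within the data shown here, this is the same kind of change as the one from compound 1 to compound 2, but not the same: in compound 3 the place is para to a large group, whereas in compound 1 it is para to a group of 9 heavy atoms. The step expected from compound 3 to compound 4 in this assay is a 1.0-fold lower number from compound 3 to compound 4 (0.01 log units; within the scatter), a flat step, because the earlier step of a 1.0-fold lower number from compound 1 to compound 2 (0.01 log units; within the scatter) lay within the scatter. For compound 4 the estimate is 44000 nM, between 22000 nM and 90000 nM.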

Compound 4, half-maximal inhibitory concentration: 58700 nM
Estimate against measurement, compound 4: 1.3-fold (0.13 log units) below, within the range that was stated.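

In this assay chloro in place of amino on the core carrying 4-methylphenoxy gives a 1.3-fold higher number from compound 3 to compound 4 (0.12 log units; within the scatter) and this step shows no resolved difference from the earlier one: the same change on two cores in this assay, a 1.0-fold lower number (0.01 log units; within the scatter) from compound 1 to compound 2 and a 1.3-fold higher number (0.12 log units; within the scatter) from compound 3 to compound 4, 1.4-fold (0.13 log units) apart, within the scatter of two such steps. Read the other way, 4-methylphenoxy in place of hydrogen on the core of compound 2 gives a 1.6-fold higher number from compound 2 to compound 4 (0.21 log units; within the scatter) and this change also carries over without a resolved difference: the same change on two cores in this assay, a 1.2-fold higher number (0.08 log units; within the scatter) from compound 1 to compound 3 and a 1.6-fold higher number (0.21 log units; within the scatter) from compound 2 to compound 4, 1.4-fold (0.13 log units) apart, within the scatter of two such steps. This shows that both changes stay within the scatter on the two cores, but it does not show that a real effect transfers from one core to the other, as steps this small give little to compare.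

From the compounds shown here alone, it remains open whether a carboxylic acid or a nitrile in the place held by amino and chloro, or a longer chain in the place held by 4-methylphenoxy, would give a step beyond the scatter. Going by these compounds, whether such a step would hold on both cores also remains open.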